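Replacing a substituted aryl amide with a methoxybenzyl amide

This account rests on a few compounds, and the source may have more. Where it says the series, first, only, none or still open, it means among the compounds named here.

Of the compounds shown here, three built on one shared core have been tested in a functional assay on K562 cells (Homo sapiens) for cytotoxicity, read by MTT assay, with a stated time of 72 h; a higher number here means a weaker inhibitor, a lower number a stronger inhibitor. Compound 1, `N#Cc1ccc(NC(=O)CN2C(=O)/C(=C/c3ccc(-c4ccc(Cl)cc4)o3)SC2=S)cc1`, gives 85000 nM in this assay. Compound 2, `O=C(CN1C(=O)/C(=C/c2ccc(-c3ccc(Cl)cc3)o2)SC1=S)NCc1ccc(F)cc1`, gives 150000 nM. Compound 3, `N#Cc1cc(NC(=O)CN2C(=O)/C(=C/c3ccc(-c4ccc(Cl)cc4)o3)SC2=S)ccc1C(F)(F)F`, reaches only a limit of the assay, > 250000 nM, so no exact number is known for it. Among the measured compounds shown here, it is the single value that sits at the limit of > 250000 nM in this assay, at which 1 of the 3 values shown sits. Among the measured steps, a 1.8-fold higher number from compound 1 to compound 2 (0.25 log units; within the scatter), whereas an at least 2.9-fold higher number from compound 1 to compound 3 (0.46 log units; beyond the scatter), and an at least 1.6-fold higher number from compound 2 to compound 3 (0.22 log units; that floor lies within the scatter). Compound 3 therefore stands at the weak end of what has been measured, though its distance from compound 2 cannot be pinned down.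

Compound 4, `COc1ccc(CNC(=O)CN2C(=O)/C(=C/c3ccc(-c4ccc(Cl)cc4)o3)SC2=S)cc1`, differs from compound 3 in one place: 4-methoxybenzyl in place of 3-cyano-4-(trifluoromethyl)phenyl on an amide-type nitrogen. For the measured compounds named here, the steps that bear on this change are the two that lead into compound 3, both of which raised the number, one of them beyond the scatter. Moving away from compound 3 toward a benzyl amide, as in compound 2, should reverse that direction. Compound 4 is expected to give about 150000 nM, within a range of 60000 nM to 250000 nM. This estimate corresponds to an expected step of an at least 1.6-fold lower number from compound 3 to compound 4 (0.22 log units; that floor lies within the scatter).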

Compound 4, half-maximal inhibitory concentration: 40000 nM
Compound 4: the middle estimate sits 3.8-fold (0.57 log units) above what was measured, and the stated range ends above it.
By their numbers in this assay, from the lowest: compound 4; then compounds 1 and 2 (each within the scatter of the next). At a limit, above all of these: compound 3.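

In this assay, the benzyl amide turns out to be sensitive to its substituent: methoxy in place of fluoro on an aromatic carbon gives a 3.8-fold lower number from compound 2 to compound 4 (0.57 log units; beyond the scatter), with the benzyl amide itself left unchanged. Compound 2 could not be told apart from compound 1, yet the methoxy compound can, with a 2.1-fold lower number from compound 1 to compound 4 (0.33 log units; beyond the scatter), so among these compounds a benzyl amide alone does not set itself apart from the 4-cyanophenyl amide, and the substituent it carries makes the difference. Exchanging the 3-cyano-4-(trifluoromethyl)phenyl group for 4-methoxybenzyl gives an at least 6.2-fold lower number from compound 3 to compound 4 (0.79 log units; beyond the scatter), which is only a floor since compound 3 has a limit and not a number: the limit of > 250000 nM in this assay, at which 1 of the 4 values shown sits.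

From the compounds shown here alone, whether the lower number belongs to methoxy itself stays open, since an unsubstituted benzyl amide, or a hydroxy, an amine or an ethoxy group in place of the methoxy, would be needed to test that. Also open, going by these compounds, is whether a phenethyl amide, with its longer chain, would keep the lower number seen for compound 4.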